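This account rests on a few compounds, and the source may have more. Where it says the series, first, only, none or still open, it means among the compounds named here.

Three compounds share one core and differ in the group hung on the ring nitrogen. Compound 1 `CCCSc1nc(N/N=C/c2ccccc2F)c2nnn(Cc3ccccc3)c2n1` carries a fluoro group; in a functional assay on ECa-109 cells (Homo sapiens) for antiproliferative activity, read by MTT assay, with a stated time of 72 h (a lower number here means a stronger inhibitor, a higher number a weaker inhibitor), compound 1 gives only a limit, > 64000 nM (the limit of > 64000 nM in this assay, at which 1 of the 3 values shown sits). Compound 2 `CCCSc1nc(N/N=C/c2ccccc2Cl)c2nnn(Cc3ccccc3)c2n1` carries a chloro group instead and gives 6180 nM, a step of an at least 10-fold lower number from compound 1 to compound 2 (1.01 log units; beyond the scatter). Compound 3 `CCCSc1nc(N/N=C(\C)c2ccc(Br)cc2)c2nnn(Cc3ccccc3)c2n1` gives 4670 nM, with an at least 13-fold lower number from compound 1 to compound 3 (1.13 log units; beyond the scatter) and a 1.3-fold lower number from compound 2 to compound 3 (0.12 log units; within the scatter); compound 3 thus holds the lowest of the two numbers, and its nearest neighbour is compound 2. Compound 4 `CCCSc1nc(N/N=C(\C)c2ccccc2)c2nnn(Cc3ccccc3)c2n1` differs from compound 3 by hydrogen in place of bromo on an aromatic carbon. The change from fluoro to chloro was large, whereas chloro to bromo was not, so removing the halogen altogether is expected to cost some potency: a 1.9-fold higher number from compound 3 to compound 4 (0.28 log units; within the scatter). Compound 4 is estimated at 9000 nM, within 3000 nM to 30000 nM.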

Compound 4, half-maximal inhibitory concentration: 32200 nM
Compound 4: middle estimate off by 3.6-fold (0.55 log units), on the low side; the whole stated range lies below it.
By their numbers in this assay, from the lowest: compounds 3 and 2 (each within the scatter of the next); then compound 4. At a limit, above all of these: compound 1.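

In this assay taking the bromo off the 4-bromophenyl group is not a neutral change: it gives a modest step, a 6.9-fold higher number from compound 3 to compound 4 (0.84 log units; beyond the scatter). So what sits at this place on the ring does matter, and the plain phenyl of compound 4 also stands apart from the chloro-bearing compound, with a 5.2-fold higher number from compound 2 to compound 4 (0.72 log units; beyond the scatter). Compound 1 stands at a limit: the limit of > 64000 nM in this assay, at which 1 of the 4 values shown sits. The step that starts from this limit gives only a floor: an at least 1.9-fold lower number from compound 1 to compound 4 (0.29 log units; that floor lies within the scatter). Still open, going by these compounds, is whether a methoxy group, an amine or a carboxylic acid at this place would serve as well as bromo. Whether iodo would do so is equally unknown.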